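This account rests on a few compounds, and the source may have more. Where it says the series, first, only, none or still open, it means among the compounds named here.

Series notes. Compound 1 `COc1ccc(-n2nncc2CN2C(=O)C3(C(C#N)=C(N)Oc4c(N)cc5nc6ccccc6nc5c43)c3ccccc32)cc1` carries a 4-methoxyphenyl on the aromatic nitrogen. In a functional assay on A549 cells (Homo sapiens) for antiproliferative activity, read by MTT assay, with a stated time of 48 h (a higher number here means a weaker inhibitor, a lower number a stronger inhibitor), compound 1 gives only a limit, > 50000 nM. Compound 2 `N#CC1=C(N)Oc2c(N)cc3nc4ccccc4nc3c2C12C(=O)N(Cc1cnnn1-c1ccc([N+](=O)[O-])cc1)c1ccccc12` carries a 4-nitrophenyl at the same nitrogen. In this assay compound 2 likewise gives only a limit, > 50000 nM. Compound 3 `Cc1cc(C)cc(-n2nncc2CN2C(=O)C3(C(C#N)=C(N)Oc4c(N)cc5nc6ccccc6nc5c43)c3ccccc32)c1` carries a 3,5-dimethylphenyl. In this assay, among the measured compounds shown here, compound 3 gives 31200 nM, the only number in the set. The step that the two limits leave unreadable from compound 1 to compound 2 cannot be read because the limit of > 50000 nM in this assay, at which 2 of the 3 values shown sit, holds both values. For the measured compounds named here, the steps of an at least 1.6-fold lower number from compound 1 to compound 3 (0.20 log units; that floor lies within the scatter) and an at least 1.6-fold lower number from compound 2 to compound 3 (0.20 log units; that floor lies within the scatter) are the only readable information on the aryl group at this nitrogen, and each sets only a floor that lies within the scatter.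

Compound 4 `N#CC1=C(N)Oc2c(N)cc3nc4ccccc4nc3c2C12C(=O)N(Cc1cnnn1-c1c(Cl)cc(Cl)cc1Cl)c1ccccc12` is the next member: 2,4,6-trichlorophenyl in place of 3,5-dimethylphenyl on an aromatic nitrogen. The two steps ending at compound 3 bear on this change, since both alter the same aryl group, and both leave the size open within the scatter; hence no step beyond the scatter is expected in this assay, though a value reported only as a limit remains possible. Compound 4 is therefore expected to give about 30000 nM in this assay, within 12000 nM to 75000 nM. That corresponds to an expected step of a 1.0-fold lower number from compound 3 to compound 4 (0.02 log units; within the scatter).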

Compound 4, half-maximal inhibitory concentration: > 50000 nM
Compound 4: a limit, no number; the forecaster's own chance of this, stated with the estimate: 30%; middle value at least 1.6-fold (0.22 log units) from the limit.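

Compound 4 gives only a limit in this assay, so a third aryl group on this aromatic nitrogen, and the first one carrying chlorine, gives no number. Going from 3,5-dimethylphenyl to 2,4,6-trichlorophenyl gives an at least 1.6-fold higher number from compound 3 to compound 4 (0.20 log units; that floor lies within the scatter), which adds a second kind of step ending at the only compound with a number, yet sets only a floor within the scatter, so compound 3 still stands apart from the others only by having a number at all. The steps among compound 1, compound 2 and compound 4 cannot be read, and these three aryl groups cannot be ranked against one another: the limit of > 50000 nM in this assay, at which 3 of the 4 values shown sit.

From the compounds shown here alone, whether any change to this aryl group moves the value beyond the scatter remains open, as only compound 3 gives a number to measure from. Also open, going by these compounds, is how a benzyl group, a longer alkyl chain, or a phenyl bearing an amine or a carboxylic acid at this nitrogen would read in this assay, and whether a change elsewhere on the shared core would bring the series into a measurable range.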